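From compound 2 to compound 4: a 4-methoxybenzyl on nitrogen

The source may hold more compounds than are shown below. What is called first, only, known or untested is meant among the compounds shown, and "the series" means these compounds.

Values in a physicochemical assay for inhibition, read by spectrophotometry, with a stated time of 10 min; on this read-out lower numbers stand for stronger inhibition and higher numbers for weaker inhibition:
compound 1 `CN(C)CCCOc1ccc(CNc2ccc3nc(N)nc(N)c3c2)cc1` gives 6380 nM
compound 2 `COc1ccc(CNc2ccc3nc(N)nc(N)c3c2)cc1` gives 5720 nM
compound 3 `Nc1nc(N)c2cc(NCc3ccc(OC(F)(F)F)cc3)ccc2n1` gives 4750 nM

Compound 2 stands within the scatter of both others, with a 1.1-fold lower number from compound 1 to compound 2 (0.05 log units; within the scatter) and a 1.2-fold lower number from compound 2 to compound 3 (0.08 log units; within the scatter). Compound 4 `COc1ccc(CN(Cc2ccc(OC)cc2)c2ccc3nc(N)nc(N)c3c2)cc1` has 4-methoxybenzyl in place of hydrogen on a nitrogen on an aromatic ring, (4-methoxybenzyl in place of hydrogen on a nitrogen on an aromatic ring). The measured steps, including a 1.3-fold lower number from compound 1 to compound 3 (0.13 log units; within the scatter), all lie at the oxygen on an aromatic ring, so they bear on this change only weakly. Going by the values given here, no measured compound tests that nitrogen. As far as these compounds go, no step beyond the scatter is expected in this assay, though either direction remains open. The expected step is a 1.1-fold lower number from compound 2 to compound 4 (0.06 log units; within the scatter). Compound 4 is estimated at 5000 nM, with an expected range of 1500 nM to 17000 nM.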

Compound 4, half-maximal inhibitory concentration: 114000 nM
Beside the measured number, compound 4's estimate is 23-fold (1.36 log units) below it; the whole stated range lies below it.
By their numbers in this assay, from the lowest: compounds 3, 2 and 1 (each within the scatter of the next); then compound 4.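

In this assay, 4-methoxybenzyl in place of hydrogen on the nitrogen on an aromatic ring brings a 20-fold higher number from compound 2 to compound 4 (1.30 log units; beyond the scatter), the only step beyond the scatter among those shown; every change at the oxygen on an aromatic ring stayed within it. This nitrogen is therefore a place where a change moves the number strongly, here towards weaker inhibition. Nothing at hand explains the step. As far as these compounds go, whether a smaller group on that nitrogen, such as an ethyl or an acetyl, is tolerated remains open, as does whether the hydrogen itself matters.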